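The source may hold more compounds than are shown below. What is called first, only, known or untested is meant among the compounds shown, and "the series" means these compounds.

Measured in an ADME assay on MT2 cells (Homo sapiens) for cytotoxicity; a lower number here means that less compound is tolerated, a higher number that more compound is tolerated:
compound 1 `CC(C)=CCOc1cc(Nc2ncnc(Cl)n2)ccc1Cl`: 45000 nM
compound 2 `CC(C)=CCOc1cc(Nc2nc(C)nc(Cl)n2)ccc1Cl`: 40000 nM
compound 3 `COc1nc(Cl)nc(Nc2ccc(Cl)c(OCC=C(C)C)c2)n1`: 26000 nM

Compound 3 is separated from compound 1 by a 1.7-fold lower number from compound 1 to compound 3 (0.24 log units; within the scatter) and from compound 2 by a 1.5-fold lower number from compound 2 to compound 3 (0.19 log units; within the scatter), both within the scatter, so the three compounds cannot be told apart in this assay. Compound 4 `COc1nc(Nc2ccc(Cl)c(OCC=C(C)C)c2)nc(OC)n1` differs from compound 3 by methoxy in place of chloro on an aromatic carbon. For the measured compounds named here, no measured step covers methoxy in place of chloro; the nearest are the two steps into compound 3, both introducing methoxy and both within the scatter, and the step from compound 1 to compound 2, a 1.1-fold lower number from compound 1 to compound 2 (0.05 log units; within the scatter), also within the scatter. A change within the scatter is therefore expected in this assay, if anything toward a lower number. Compound 4 is estimated at 22000 nM, between 10000 nM and 50000 nM. This estimate means a 1.2-fold lower number from compound 3 to compound 4 (0.07 log units; within the scatter), expected within the scatter.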

Compound 4, half-maximal cytotoxic concentration: 20000 nM
Compound 4: the middle estimate sits 1.1-fold (0.04 log units) above what was measured; measured number inside the range.
By their numbers in this assay, from the lowest: compounds 4, 3, 2 and 1 (each within the scatter of the next, the first and the last beyond it).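

Methoxy in place of chloro, on the aromatic carbon between two ring nitrogen atoms, gives a 1.3-fold lower number from compound 3 to compound 4 (0.11 log units; within the scatter) in this assay. For the compounds shown here, compounds 1, 2 and 3 all keep chloro at this position, so compound 4 is the first to show that this chloro can be replaced without a change beyond the scatter. No measurement is available that bears on why the number holds.

From the compounds shown here alone, whether an amine or a longer alkoxy chain at this position would also stay within the scatter remains open.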